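A few compounds are considered here, and "the series" means these few. Any claim that something is new, unique, unknown or untested is made for them only; others in the source may bear on it.

Measured so far in a functional assay on HEK293 cells for agonist activity at Motilin receptor (Homo sapiens), read by FLIPR; on this read-out lower numbers stand for an effect already at smaller amounts and higher numbers for an effect only at larger amounts of compound:

Compound 1 `C[C@@H]1CN(Cc2ccc(-c3ccccc3C(=O)N3CCC(Cc4ccc(F)cc4)CC3)cc2)C[C@H](C)N1` gives 10 nM.
Compound 2 `C[C@@H]1CN(Cc2ccc(-c3ccccc3C(=O)N3CCC(Oc4ccc(F)cc4)CC3)cc2)C[C@H](C)N1` gives 63.1 nM.

Compound 2 therefore holds the higher of the two numbers, with compound 1 clearly lower. Compound 3 `C[C@@H]1CN(Cc2ccc(-c3ccccc3C(=O)N3CCC(C(=O)c4ccc(F)cc4)CC3)cc2)C[C@H](C)N1` differs from compound 2 in one place: (4-fluorophenyl)carbonyl in place of 4-fluorophenoxy on a saturated ring carbon. Within the data shown here, the only measured step at this ring carbon, a 6.3-fold higher number from compound 1 to compound 2 (0.80 log units; beyond the scatter), shows that exchanging the group there moves the number modestly. No carbonyl linker has been measured, so the direction is uncertain. Compound 3 is expected to land between the two measured values, with the step of a 1.6-fold lower number from compound 2 to compound 3 (0.20 log units; within the scatter). For compound 3 the estimate is 40 nM, within 10 nM to 160 nM.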

Compound 3, half-maximal effective concentration: 63.1 nM
For compound 3 the middle estimate is 1.6-fold (0.20 log units) below the measured one, and the stated range covers the measured number.
By their numbers in this assay, from the lowest: compound 1; then compounds 2 and 3 (each within the scatter of the next).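

In this assay, (4-fluorophenyl)carbonyl in place of 4-fluorophenoxy gives no change at the digits printed from compound 2 to compound 3 (within the scatter) on this saturated ring carbon, so these two groups cannot be told apart here. Against 4-fluorobenzyl, the new group gives a 6.3-fold higher number from compound 1 to compound 3 (0.80 log units; beyond the scatter) and so matches the earlier gap, leaving compound 1 alone with the lowest number. Nothing measured here bears on the reason for this. On these data alone, whether an amine link or a longer chain carrying the same 4-fluorophenyl ring would approach compound 1 remains open.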